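A few compounds are considered here, and "the series" means these few. Any claim that something is new, unique, unknown or untested is made for them only; others in the source may bear on it.

Measured in a functional assay on MDA-MB-231 cells (Homo sapiens) for antiproliferative activity, read by MTT assay, with a stated time of 24 h; on this read-out lower numbers stand for stronger inhibition and higher numbers for weaker inhibition:
Compound 1 `COc1ccccc1C(=O)NC(CC(=O)O)c1ccc(C(C)(C)C)cc1` gives > 100000 nM, which is a limit of the assay.
Compound 2 `COc1ccc(C(=O)NC(CC(=O)O)c2ccc(C(C)(C)C)cc2)cc1` gives > 100000 nM, also a limit of the assay.
Compound 3 `COc1ccc(C(=O)NC(CC(=O)O)c2ccc(Cl)cc2Cl)cc1` gives > 100000 nM, again a limit of the assay.

None of the three compounds reaches a readable number in this assay; all of them sit at the limit of > 100000 nM in this assay, at which 3 of the 3 values shown sit. Compound 1 and compound 2 differ in one place only, (2-methoxyphenyl in place of 4-methoxyphenyl on a carbonyl carbon), and the corresponding step that the two limits leave unreadable from compound 2 to compound 1 therefore has no readable size. Compound 2 and compound 3 differ in their cores, and that difference is not broken down here.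

Compound 4 `COc1ccccc1C(=O)NC(CC(=O)O)c1ccc(Cl)cc1Cl` is not yet measured. It differs from compound 3 by 2-methoxyphenyl in place of 4-methoxyphenyl on a carbonyl carbon, the same change at the same place that separates compound 1 from compound 2. Going by the values given here, the only earlier instance of this change left both ends at the limit, and compound 3 itself stands at the limit, so there is nothing to suggest that the change alone will bring compound 4 into the readable range. Compound 4 is accordingly expected to give about 200000 nM in this assay, most likely again reported as a limit, with a range from 100000 nM to 1000000 nM. The step this expectation implies, a step that the limit leaves unreadable from compound 3 to compound 4, is itself expected to be unreadable.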

Compound 4, half-maximal inhibitory concentration: > 100000 nM
Compound 4 was reported as a limit (the forecaster's own chance of this, stated with the estimate: 85%); the middle value is on the limit's open side.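

Going by these compounds alone, compound 3 and compound 4 both stand at a limit of the assay, so the step between them, 2-methoxyphenyl in place of 4-methoxyphenyl, cannot be read and no new step comes from this result. The compounds shown leave open whether any change to the shared core gives a readable value at all.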